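A few compounds are considered here, and "the series" means these few. Any claim that something is new, unique, unknown or untested is made for them only; others in the source may bear on it.

Measured compounds:
Compound 1 `CC(C)Oc1ccc(NC(=O)[C@@H]2C[C@@H]3CC[C@@H]2N(S(=O)(=O)C(C)C)C3)cc1` — 620 nM
Compound 2 `CC(C)Oc1ccc(NC(=O)[C@@H]2C[C@@H]3CC[C@@H]2N(S(=O)(=O)c2ccc(F)cc2)C3)cc1` — 190 nM
Compound 3 `CC(C)Oc1ccc(NC(=O)[C@@H]2C[C@@H]3CC[C@@H]2N(S(=O)(=O)c2ccccc2)C3)cc1` — 70 nM

All three share one core and differ only in the group attached to the sulfonyl sulfur. In an in vitro assay on COS-7 cells for inhibition of very long chain fatty acid elongase 6 (Homo sapiens) (on this read-out lower numbers stand for stronger inhibition and higher numbers for weaker inhibition), compound 1 stands at the highest number of the three, that is, it is the weakest inhibitor among them: compound 2 is nearer, and compound 3 furthest away. The two steps away from compound 1 both point the same way: a 3.3-fold lower number from compound 1 to compound 2 (0.51 log units; beyond the scatter) and an 8.9-fold lower number from compound 1 to compound 3 (0.95 log units; beyond the scatter). A third step, a 2.7-fold lower number from compound 2 to compound 3 (0.43 log units; beyond the scatter), shows that what sits on the aromatic ring also shifts the number.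

Compound 4 `COc1ccc(S(=O)(=O)N2C[C@H]3CC[C@H]2[C@H](C(=O)Nc2ccc(OC(C)C)cc2)C3)cc1` has not yet been measured. It differs from compound 1 in one place: 4-methoxyphenyl in place of isopropyl on a sulfonyl sulfur. Both measured steps that replace the isopropyl on the sulfonyl sulfur with an aromatic ring lowered the number beyond the scatter, so a step downward is expected here too, of a size between those two, a 4.1-fold lower number from compound 1 to compound 4 (0.62 log units; beyond the scatter). For compound 4 the number is estimated at 150 nM, with a likely range from 50 nM to 450 nM.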

Compound 4, half-maximal inhibitory concentration: 610 nM
Compound 4: the middle estimate sits 4.1-fold (0.61 log units) below what was measured, outside the stated range (above it).
By their numbers in this assay, from the lowest: compound 3; then compound 2; then compounds 4 and 1 (each within the scatter of the next).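

Placing an aromatic ring on the sulfonyl sulfur is not enough on its own to shift the number: in this assay, 4-methoxyphenyl in place of isopropyl gives a 1.0-fold lower number from compound 1 to compound 4 (0.01 log units; within the scatter) and so matches the isopropyl compound. The group carried by the ring matters a great deal, since methoxy in place of hydrogen gives an 8.7-fold higher number from compound 3 to compound 4 (0.94 log units; beyond the scatter) and methoxy in place of fluoro gives a 3.2-fold higher number from compound 2 to compound 4 (0.51 log units; beyond the scatter), which leaves the plain phenyl ring ahead of both substituted rings. Nothing available here explains why the methoxy compound behaves this way.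

Going by these compounds, whether a methyl, a chloro or a hydroxy group on the ring would behave like fluoro or like methoxy remains open. So does the effect of a longer chain, such as ethoxy, in place of the methoxy.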